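The compounds below may be only part of what the source reports. "The series", "measured", "known", "first", "only" and "open" are said of these compounds alone.

Measured so far:
- compound 1, `Cc1[nH]c2ccccc2c1C(C1=C(O)C(=O)c2ccccc2C1=O)c1ccc(Cl)cc1`: 8030 nM
- compound 2, `O=C1C(O)=C(C(c2ccc([N+](=O)[O-])cc2)c2c(-c3ccccc3)[nH]c3ccccc23)C(=O)c2ccccc21`: 6770 nM

Both compounds share the same core, and each carries a different group on the five-membered ring of the fused system as well as a different substituent on the pendant benzene ring. In a functional assay on HeLa cells (Homo sapiens) for cytotoxicity, read by MTT assay, with a stated time of 48 h (a higher number here means a weaker inhibitor, a lower number a stronger inhibitor), compound 1 gives 8030 nM, which is the higher of the two numbers recorded so far. In this assay compound 2 gives 6770 nM. The gap between these two values is within the usual scatter of repeated measurements, so the data do not show one compound to be stronger or weaker than the other.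

Compound 3, `O=C1C(O)=C(C(c2ccc(Cl)cc2)c2c[nH]c3ccccc23)C(=O)c2ccccc21`, has not yet been measured. It differs from compound 1 in one place: hydrogen in place of methyl on an aromatic carbon. Within the data shown here, no step between two measured compounds that differ in only one place is available here, so there is no measured precedent for this kind of change.

Given how small the change is, the expected step from compound 1 to compound 3 is a 1.1-fold higher number from compound 1 to compound 3 (0.05 log units; within the scatter), that is, nothing beyond the scatter. Compound 3 is therefore estimated at 9000 nM in this assay, with a likely range from 4000 nM to 20000 nM.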

Compound 3, half-maximal inhibitory concentration: 37000 nM
Estimate against measurement, compound 3: 4.1-fold (0.61 log units) below, and the stated range ends below it.
By their numbers in this assay, from the lowest: compounds 2 and 1 (each within the scatter of the next); then compound 3.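

In this assay, the methyl group on the aromatic carbon next to the ring nitrogen proves to matter: replacing it with hydrogen, the change from 2-methyl-1H-indol-3-yl to 1H-indol-3-yl, gives a 4.6-fold higher number from compound 1 to compound 3 (0.66 log units; beyond the scatter) and so a weaker inhibitor. Among these compounds, this is the only measured step that changes a single place, and it shows that losing just one carbon atom at this position can move the result beyond the usual scatter of repeated measurements. Nothing available here explains why the methyl group counts at this position.

The compounds shown leave open whether a longer chain such as ethyl, or a different kind of group such as an amine, would match methyl at this position, improve on it, or lose the effect altogether. They also leave open whether replacing methyl with hydrogen would give a step of similar size if the chlorine on the pendant benzene ring of compound 1 were exchanged for another group, such as methoxy.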